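Three flat readings and a diethylcarbamoyl swap

This account rests on a few compounds, and the source may have more. Where it says the series, first, only, none or still open, it means among the compounds named here.

- compound 1 `CCOC(=O)Cn1c(=O)c(-c2ccc(OC)cc2)cc2c(OC)cc(OC)cc21`: 10000 nM
- compound 2 `COc1ccc(-c2cc3c(OC)cc(OC)cc3n(CC(=O)O)c2=O)cc1`: 10000 nM
- compound 3 `COC(=O)CCn1c(=O)c(-c2ccc(OC)cc2)cc2c(OC)cc(OC)cc21`: 10000 nM

All three readings come from a functional assay on MCF7 cells (Homo sapiens) for cytotoxicity, read by colorimetric assay and MTT assay; a higher number here means a weaker inhibitor, a lower number a stronger inhibitor. Compounds 1 and 2 share the same value as compound 3, at 10000 nM, so compound 3 stands level with both.

Compound 4 `CCN(CC)C(=O)CCn1c(=O)c(-c2ccc(OC)cc2)cc2c(OC)cc(OC)cc21` keeps the shared core and alters only the end of the chain on compound 3: diethylamino in place of methoxy on a carbonyl carbon. In words, diethylamino takes the place of methoxy on a carbonyl carbon, which turns 2-(methoxycarbonyl)ethyl into 2-(diethylcarbamoyl)ethyl.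

Among the compounds with values here, no measured compound carries a diethylcarbamoyl group, so no measured step matches this change. The three nearest steps all alter the same chain end. Removing the ethyl from the ester gave no change at the digits printed from compound 1 to compound 2 (within the scatter). Placing (methoxycarbonyl)methyl where ethoxycarbonyl stood gave no change at the digits printed from compound 1 to compound 3 (within the scatter), and placing it where carboxy stood gave no change at the digits printed from compound 2 to compound 3 (within the scatter). None of these steps moved the reading, so the expected step is no change at the digits printed from compound 3 to compound 4 (within the scatter), with no direction favoured. Three compounds are thin evidence for a new group, so the range stays fairly wide.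

For compound 4 the estimated value in this assay is 10000 nM, with an expected range from 4000 nM to 20000 nM.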

Compound 4, half-maximal inhibitory concentration: 10000 nM
Compound 4: the middle estimate sits on the measured number at the digits printed; low and high end bracket the measured number.
By their numbers in this assay, from the lowest: compounds 1, 2, 3 and 4 (each within the scatter of the next).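

Within the data shown here, this is the first nitrogen-linked group at the carbonyl carbon of this chain. In this assay, diethylamino in place of methoxy, a group of 5 heavy atoms replacing one of 2, gives no change at the digits printed from compound 3 to compound 4 (within the scatter), so 2-(diethylcarbamoyl)ethyl reads the same as 2-(methoxycarbonyl)ethyl here. The comparisons with the shorter-chain compounds agree: (diethylcarbamoyl)methyl in place of carboxy gives no change at the digits printed from compound 2 to compound 4 (within the scatter), and (diethylcarbamoyl)methyl in place of ethoxycarbonyl gives no change at the digits printed from compound 1 to compound 4 (within the scatter), so the ester, the carboxylic acid and the diethylcarbamoyl end all sit level in these four compounds. Nothing measured here offers an explanation for this flat reading.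

On these data alone, whether a primary amine or a hydroxyl at the end of the chain, or a much longer chain, would shift the reading remains open. All four compounds share the same core and the same reading, so they cannot show which parts of the structure, if any, can move the value in this assay.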